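A Further Hydroxy Group on Compound 3

A few compounds are considered here, and "the series" means these few. Any claim that something is new, unique, unknown or untested is made for them only; others in the source may bear on it.

Of the compounds shown here, three sharing one core have been tested in an ADME assay on BV-2 cells (Mus musculus) for cytotoxicity, read by MTT assay, with a stated time of 24 h; on this read-out higher numbers stand for lower toxicity in this test and lower numbers for higher toxicity in this test: compound 1 `Cc1c2c(cc(C(C)C)cc1=O)[C@@H](C)CC2`, compound 2 `Cc1c2c(cc(C(C)C)cc1=O)[C@@H](C)C[C@@H]2O` and compound 3 `Cc1c2c(cc(C(C)C)cc1=O)[C@@H](C)C[C@H]2O`. In this assay compound 1 gives 76000 nM, compound 2 gives 35000 nM and compound 3 gives 78000 nM. Compound 3 therefore stands level with compound 1 at the upper end of these numbers, clear of compound 2. The next candidate is compound 4 `CC(C)c1cc2c(c(CO)c(=O)c1)[C@H](O)C[C@@H]2C`, and the change is hydroxy in place of hydrogen on a saturated chain carbon bound to an aromatic carbon, or methyl to hydroxymethyl.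

The nearest precedents put hydroxy in place of hydrogen on a saturated ring carbon instead. That change gave a 2.2-fold lower number from compound 1 to compound 2 (0.34 log units; beyond the scatter) in one configuration and a 1.0-fold higher number from compound 1 to compound 3 (0.01 log units; within the scatter) in the other. The gap between these two outcomes, a 2.2-fold higher number from compound 2 to compound 3 (0.35 log units; beyond the scatter), comes with the fact that compounds 2 and 3 differ only in the configuration as drawn. Neither precedent sits at the new place, so they offer only a rough guide: no change, or a modest fall at most. The expected step is a 1.4-fold lower number from compound 3 to compound 4 (0.15 log units; within the scatter), a small one towards lower numbers. For compound 4 the estimated value is 55000 nM, with an expected range of 25000 nM to 120000 nM.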

Compound 4, half-maximal cytotoxic concentration: 74000 nM
Beside the measured number, compound 4's estimate is 1.3-fold (0.13 log units) below it, and the stated range covers the measured number.
By their numbers in this assay, from the lowest: compound 2; then compounds 4, 1 and 3 (each within the scatter of the next).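

With a 1.1-fold lower number from compound 3 to compound 4 (0.02 log units; within the scatter) in this assay, hydroxy in place of hydrogen on a saturated chain carbon bound to an aromatic carbon, or methyl to hydroxymethyl, leaves the number where it stood. Going by these compounds alone, the earlier compounds showed a hydroxy only on a saturated ring carbon, where the outcome differed between the two configurations, so compound 4 gives the first reading at this chain position and shows that, on compound 3, the added hydroxy there brings no change beyond the scatter. Nothing given here bears on why the number holds at this position.

On these data alone, the step has been read on compound 3 alone, so it remains open whether methyl to hydroxymethyl would behave in the same way on compound 1, which has no ring hydroxy, or on compound 2, which carries it in the other configuration. As far as these compounds go, it also remains open whether the number would hold with a different group at this place, such as a carboxylic acid, an amine or a longer chain like hydroxyethyl.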